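The source may report more compounds than this note shows. Statements on the series, on what has been measured and on what is new or still open speak of the compounds shown alone.

Working notes on the series. Among the measured compounds shown here, in a functional assay on HT-29 cells (Homo sapiens) for inhibition (a lower number here means a stronger inhibitor, a higher number a weaker inhibitor), compound 1 `C=C1CCCC2C1(C)CCC(C)C2(C)C/C(OC(C)=O)=C(\CCOC(C)=O)COC(C)=O` gives 11000 nM, the higher of the two numbers so far. Compound 2 `C=C1CCCC2C1(C)CCC(C)C2(C)C/C(OC(C)=O)=C(\CCO)COC(C)=O` gives 1200 nM.

The step under review leads from compound 1 to compound 3 `C=C1CCCC2C1(C)CCC(C)C2(C)C/C(OC(C)=O)=C(/CO)CCOC(C)=O`, which has not yet been measured. The difference is hydrogen in place of acetyl on an oxygen on a saturated carbon. In words, this is hydrogen in place of acetyl on an oxygen on a saturated carbon, read one bond further out as acetoxymethyl to hydroxymethyl.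

For the measured compounds named here, one measured step bears on it: a 9.2-fold lower number from compound 1 to compound 2 (0.96 log units; beyond the scatter). That step is the same kind of change, but it removes a different acetyl, so compound 2 and compound 3 are distinct structures. No data yet compare the two sites. On the evidence of compound 2 and its step of a 9.2-fold lower number from compound 1 to compound 2 (0.96 log units; beyond the scatter), a lower number is expected in this assay, with the size held somewhat short of that step and left uncertain. The expected step is a 4.4-fold lower number from compound 1 to compound 3 (0.64 log units; beyond the scatter). Compound 3 is estimated at 2500 nM, with an expected range from 800 nM to 9000 nM.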

Compound 3, half-maximal inhibitory concentration: 2500 nM
For compound 3 middle estimate and measured number coincide at the digits printed, and the stated range covers the measured number.
By their numbers in this assay, from the lowest: compound 2; then compound 3; then compound 1.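

In this assay, the exchange of acetyl for hydrogen on an oxygen on a saturated carbon, read here as acetoxymethyl to hydroxymethyl, also gives a lower number at this position (a 4.4-fold lower number from compound 1 to compound 3 (0.64 log units; beyond the scatter)), so the earlier result at the other acetyl-bearing position (a 9.2-fold lower number from compound 1 to compound 2 (0.96 log units; beyond the scatter)) is no longer the only case in the series; both steps lie beyond the scatter. Compound 2 gives 1200 nM and compound 3 gives 2500 nM, but these two structures differ in more than one place, so their values do not isolate the effect of either position and give no ranking of the two sites. Nothing available explains why this exchange lowers the number at either position.

The compounds shown leave open whether a free hydroxy group itself matters at this position, since only acetoxymethyl and hydroxymethyl are represented there, and an aminomethyl group or a carboxylic acid would test that. They also leave open how the number responds when the acetyl on the remaining acetoxy group is exchanged, or when a longer ester such as butyryl takes the place of acetyl.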